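Binding notes on compounds 1 to 3

The compounds below may be only part of what the source reports. "The series", "measured", "known", "first", "only" and "open" are said of these compounds alone.

Measured so far:
compound 1 `Cc1cc(C(=O)NC(C)(C)C)nn1Cc1cc(Cl)cc2cc(-c3ccccc3)oc12` — 10 nM
compound 2 `Cc1cc(NC(=O)C2(F)CCNCC2)nn1Cc1cc(Cl)cc2cc(-c3ccccc3)oc12` — 39.8 nM

Both numbers come from an assay on CHO-K1 cells for displacement of a labelled ligand from prostaglandin E2 receptor EP1 subtype (Homo sapiens), read by scintillation counting, with a stated time of 45 min; a lower number here means a stronger inhibitor, a higher number a weaker inhibitor. Compound 2 gives the highest of the two numbers; its nearest neighbour is compound 1, reached by a 4.0-fold higher number from compound 1 to compound 2 (0.60 log units; beyond the scatter), a step that lies beyond the scatter.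

Compound 3 `Cc1cc(C(=O)NC[C@H]2CCCO2)nn1Cc1cc(Cl)cc2cc(-c3ccccc3)oc12` is not yet measured. It differs from compound 2 in one place: ((oxolan-2-yl)methyl)carbamoyl in place of ((4-fluoropiperidin-4-yl)carbonyl)amino on an aromatic carbon. Among the compounds with values here, the only measured step that bears on this is a 4.0-fold higher number from compound 1 to compound 2 (0.60 log units; beyond the scatter), which shows the measured set being moved away from a carbamoyl group on that aromatic carbon, toward the carbonylamino group of compound 2. Compound 3 returns to a carbamoyl group, now carrying an oxolan-2-ylmethyl substituent instead of the tert-butyl of compound 1. Within the data shown here, no step in the measured set tells how the oxolanylmethyl and tert-butyl substituents compare.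

The expectation, resting on compound 1 and compound 2, is therefore a lower number for compound 3, with a step of about a 2.7-fold lower number from compound 2 to compound 3 (0.42 log units; beyond the scatter). The estimated value for compound 3 in this assay is 15 nM, within a range of 5 nM to 50 nM.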

Compound 3, half-maximal inhibitory concentration: 6.31 nM
Compound 3: middle estimate off by 2.4-fold (0.38 log units), on the high side; low and high end bracket the measured number.
By their numbers in this assay, from the lowest: compounds 3 and 1 (each within the scatter of the next); then compound 2.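

In this assay, the carbamoyl group on this aromatic carbon now stands with a second substituent, as ((oxolan-2-yl)methyl)carbamoyl in place of ((4-fluoropiperidin-4-yl)carbonyl)amino gives a 6.3-fold lower number from compound 2 to compound 3 (0.80 log units; beyond the scatter) as a step in the opposite direction to the one that led away from the carbamoyl group of compound 1. On the amide-type nitrogen, (oxolan-2-yl)methyl in place of tert-butyl gives a 1.6-fold lower number from compound 1 to compound 3 (0.20 log units; within the scatter) and so does not separate the two substituents, which shows that the carbamoyl series at this position is not confined to the tert-butyl group of compound 1. No measurement here speaks to the reason for either step.

The compounds shown leave open whether the higher number of compound 2 follows from the reversed carbonylamino link or from the 4-fluoropiperidin-4-yl group, since the two change together in every step that involves compound 2. They also leave open what the defined stereocentre of compound 3 contributes, and how the carbamoyl group would respond to a substituent carrying an amine or a carboxylic acid.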